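Chloromethylbenzyl purines: second ring chloro on compound 2

The compounds below may be only part of what the source reports. "The series", "measured", "known", "first", "only" and "open" are said of these compounds alone.

Two compounds of the series carry measured numbers. Compound 1 `ClCc1ccccc1Cn1cnc2c(Cl)ncnc21` and compound 2 `ClCc1cccc(Cn2cnc3c(Cl)ncnc32)c1` differ in where the chloromethyl group sits on the benzyl ring. In a functional assay on HCT-15 cells (Homo sapiens) for cytotoxicity, read by sulforhodamine B assay, with a stated time of 48 h (on this read-out lower numbers stand for higher toxicity in this test and higher numbers for lower toxicity in this test), compound 1 gives 43700 nM, while compound 2 gives 10000 nM. Compound 2 thus stands with the lowest of the two numbers; its gap to compound 1 lies beyond the usual scatter. Compound 3 `ClCc1cccc(Cn2cnc3c(Cl)nc(Cl)nc32)c1` is not yet measured and follows from compound 2 by chloro in place of hydrogen on an aromatic carbon, the entering chloro placed on an aromatic carbon of the six-membered aromatic ring with 2 nitrogen, between two ring nitrogen atoms, meta to a chloro group. Going by the values given here, no measured pair shows this change, so its effect is not known from the data. A modest step toward lower numbers, or none beyond the scatter, is expected. Compound 3 is expected to give 7000 nM in this assay, with a range of 2500 nM to 25000 nM. The estimated step is a 1.4-fold lower number from compound 2 to compound 3 (0.15 log units; within the scatter).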

Compound 3, concentration lethal to 50% of the cells: > 100000 nM
Compound 3: a limit, no number (the forecaster's own chance of this, stated with the estimate: 10%); middle value at least 14-fold (1.15 log units) away from the limit.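

Chloro in place of hydrogen on an aromatic carbon, between two ring nitrogen atoms, is a change on the shared core itself, and in this assay it gives an at least 10-fold higher number from compound 2 to compound 3 (1.00 log units; beyond the scatter). Compound 1 and compound 2 compared only the place of the chloromethyl group on the benzyl ring, so this position on the core is the one shown here to weigh on the read-out, toward lower toxicity in this test. The reading of compound 3 is a limit of the assay and not a number: the limit of > 100000 nM in this assay, at which 1 of the 3 values shown sits.

On these data alone, the full size of the step stays open, as does whether it belongs to chloro itself or to any group at this position; an amine or a methoxy group there would separate the two. Also open, as far as these compounds go, is whether the same change on the core of compound 1 moves the read-out in the same direction.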